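Amide tail ring size in a cytotoxicity series

The source may report more compounds than this note shows. Statements on the series, on what has been measured and on what is new or still open speak of the compounds shown alone.

Measured so far:
Compound 1 `Nc1ccc(-c2nc3cc(Cl)c(Cl)cc3[nH]2)cc1` gives 30000 nM in an ADME assay on BHK cells (Mesocricetus auratus) for cytotoxicity, read by MTT assay, with a stated time of 96 h; a lower number here means that less compound is tolerated, a higher number that more compound is tolerated.
Compound 2 `O=C(CN1CCCC1)Nc1ccc(-c2nc3cc(Cl)c(Cl)cc3[nH]2)cc1` gives 64000 nM in this assay.

Among the measured compounds shown here, compound 2 stands at the highest of the two numbers in this assay; its nearest neighbour is compound 1, and the single step so far, a 2.1-fold higher number from compound 1 to compound 2 (0.33 log units; beyond the scatter), is a modest one that adds the whole amide tail to the shared core. Compound 3 `O=C(CN1CCCCC1)Nc1ccc(-c2nc3cc(Cl)c(Cl)cc3[nH]2)cc1` differs from compound 2 as follows: piperidin-1-yl in place of pyrrolidin-1-yl on a saturated chain carbon bound to a carbonyl carbon. For the measured compounds named here, no measured step changes the ring within the amide tail, so nothing bears directly on this change; the step of a 2.1-fold higher number from compound 1 to compound 2 (0.33 log units; beyond the scatter) only shows that the tail itself is tolerated about as well as its absence. Accordingly no step beyond the scatter is expected in this assay for this change. For compound 3 the estimated value in this assay is 64000 nM, with a range of 32000 nM to 128000 nM. This estimate corresponds to an expected step of no change at the digits printed from compound 2 to compound 3 (within the scatter).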

Compound 3, half-maximal cytotoxic concentration: 39000 nM
Compound 3: middle estimate off by 1.6-fold (0.22 log units), on the high side, within the range that was stated.
By their numbers in this assay, from the lowest: compounds 1, 3 and 2 (each within the scatter of the next, the first and the last beyond it).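

The change from pyrrolidin-1-yl to piperidin-1-yl on a saturated chain carbon bound to a carbonyl carbon now has a direct reading in this assay (a 1.6-fold lower number from compound 2 to compound 3 (0.22 log units; within the scatter)), and at this position the two rings are not separated beyond the scatter. The piperidin-1-yl tail also stays within the scatter of the free amine (a 1.3-fold higher number from compound 1 to compound 3 (0.11 log units; within the scatter)), whereas the pyrrolidin-1-yl tail in compound 2 is the only tail printed beyond the scatter of compound 1, and only modestly so. No measurement at hand offers an explanation for these steps.

As far as these compounds go, whether a morpholine ring, an open-chain dimethylamine or a longer chain between the carbonyl and the ring would stay within the same scatter remains open. From the compounds shown here alone, whether the ring change reads the same way on a core other than the shared core is also open.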